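The source may hold more compounds than are shown below. What is called first, only, known or untested is meant among the compounds shown, and "the series" means these compounds.

Within the data shown here, compound 1, with the structure `COc1cc2c(Oc3ccc(NC(=O)c4cn(-c5c(C)cccc5C)nn4)cc3F)ccnc2cc1OCCCN1CCCCC1`, is the only member of this small set that carries a number: in a functional assay on MKN-45 cells (Homo sapiens) for cytotoxicity, read by MTT assay, with a stated time of 72 h (on this read-out higher numbers stand for weaker inhibition and lower numbers for stronger inhibition), compound 1 gives 2140 nM. Among the measured compounds shown here, compound 2, with the structure `COc1cc2c(Oc3ccc(NC(=O)c4cn(-c5c(Cl)cccc5Cl)nn4)cc3F)ccnc2cc1OCCCN1CCCCC1`, shares the whole of that framework but bears two chlorine atoms in place of the two methyl groups on the aryl ring attached to the triazole nitrogen; for compound 2 the outcome in this assay is recorded as "not determined" (no result reported), so no number stands for it and no step to any other compound can be drawn. Compound 3, with the structure `COc1cc2c(Oc3ccc(NC(=O)c4cn(-c5ccc(F)c(F)c5)nn4)cc3F)ccnc2cc1OCCCN1CCCCC1`, is the next point of comparison. It differs from compound 2 by 3,4-difluorophenyl in place of 2,6-dichlorophenyl on an aromatic nitrogen. Because there is no measured value for compound 2, no direction or size of step between these two compounds in this assay can be stated; the expectation for compound 3 rests on compound 1 alone. Compound 3 is therefore estimated at 2000 nM, with a plausible range from 500 nM to 8000 nM.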

Compound 3, half-maximal inhibitory concentration: 310 nM
Compound 3: the middle estimate sits 6.5-fold (0.81 log units) above what was measured; the whole stated range lies above it.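

In this assay, putting 3,4-difluorophenyl in place of 2,6-dimethylphenyl on the aromatic nitrogen gives a 6.9-fold lower number from compound 1 to compound 3 (0.84 log units; beyond the scatter) and so shows that the number responds to the aryl group carried at this position, which a single measured compound could not show. On these data alone, the step from compound 2 to compound 3 cannot be read, since compound 2 has no number, and the effect of its 2,6-dichlorophenyl group stays unknown. Nothing measured here explains the difference between compound 1 and compound 3.

The change from compound 1 to compound 3 alters both the substituent and where it sits on the phenyl ring, and the compounds shown do not separate the two. As far as these compounds go, neither 3,4-dimethylphenyl nor 2,6-difluorophenyl appears among them, and neither does unsubstituted phenyl, so how each contributes remains open.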